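The source may hold more compounds than are shown below. What is called first, only, known or untested is meant among the compounds shown, and "the series" means these compounds.

Measured so far in a functional assay on DU-145 cells (Homo sapiens) for inhibition; on this read-out higher numbers stand for weaker inhibition and lower numbers for stronger inhibition:
- compound 1 `Oc1ccccc1-c1cc(-c2ccc(F)cc2)cc(-c2ccccc2O)n1`: > 50000 nM, a limit of the assay and not a number
- compound 2 `Oc1ccccc1-c1cc(-c2ccccc2C(F)(F)F)cc(-c2ccccc2O)n1`: 4770 nM

Going by the values given here, compound 2 holds the only actual number, as the one other value is a limit. Compound 3 `Oc1ccccc1-c1cc(-c2ccc(C(F)(F)F)cc2)cc(-c2ccccc2O)n1` has 4-(trifluoromethyl)phenyl in place of 2-(trifluoromethyl)phenyl on an aromatic carbon, opposite the ring nitrogen: 4-(trifluoromethyl)phenyl in place of 2-(trifluoromethyl)phenyl on an aromatic carbon.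

Among the compounds with values here, only one measured step bears on this change. The large step of an at least 10-fold lower number from compound 1 to compound 2 (1.02 log units; beyond the scatter) exchanges 4-fluorophenyl for 2-(trifluoromethyl)phenyl, so the change of group and the change of place cannot be separated. Compound 3 keeps the trifluoromethyl of compound 2 but has a 4-substituted phenyl like that of compound 1, so only part of that gain is expected to survive.

The expected move in this assay is a 2.5-fold higher number from compound 2 to compound 3 (0.40 log units; beyond the scatter), toward weaker inhibition and smaller than the measured step. For compound 3 the estimated value is 12000 nM, with an expected range from 3000 nM to 50000 nM.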

Compound 3, half-maximal inhibitory concentration: > 50000 nM
Compound 3 gave a limit, no number (the forecaster's own chance of this, stated with the estimate: 25%); at least 4.1-fold (0.61 log units) between middle value and limit.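

In this assay, exchanging 2-(trifluoromethyl)phenyl for 4-(trifluoromethyl)phenyl, with the same atoms joined differently, gives an at least 10-fold higher number from compound 2 to compound 3 (1.02 log units; beyond the scatter). The earlier step changed both group and place on the phenyl together, whereas this one shows that trifluoromethyl alone does not carry the gain at this carbon opposite the ring nitrogen, and that where it sits on the phenyl decides the read-out. The step from compound 1 to compound 3 cannot be read, and neither compound can be ranked against the other, as both values are limits and not numbers: the limit of > 50000 nM in this assay, at which 2 of the 3 values shown sit.

Open, as far as these compounds go, is whether the number of compound 2 depends on trifluoromethyl itself or would also hold for another group in its place on the phenyl. A 2-chlorophenyl or 2-methoxyphenyl on the shared core would bear on that.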